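A few compounds are considered here, and "the series" means these few. Any claim that something is new, unique, unknown or untested is made for them only; others in the source may bear on it.

Within the data shown here, in a functional assay on HUVEC cells (Homo sapiens) for inhibition, using NADPH, with a stated time of 2 h (on this read-out lower numbers stand for stronger inhibition and higher numbers for weaker inhibition), compound 1 (`Cc1c(COCCCCO)[nH]c2ccccc2c1=O`) gives 2600 nM as the higher of the two numbers so far, which makes it the weaker inhibitor of the pair. Compound 2 (`Cc1c(COc2cccc(OCC3CCOCC3)c2)[nH]c2ccccc2c1=O`) gives 8.9 nM on the same read-out, a gap well beyond the usual scatter. Compound 3 (`Cc1c(COCCCCOCC2(C)COC2)[nH]c2ccccc2c1=O`) has not yet been measured. It takes compound 1 and puts (3-methyloxetan-3-yl)methyl in place of hydrogen on an oxygen on a saturated carbon, so that hydroxy becomes (3-methyloxetan-3-yl)methoxy. Among the measured compounds shown here, no measured pair isolates this change, and only two values bear on it. Compound 2 at 8.9 nM shows that the shared core can reach far lower numbers with another side chain, so a move towards lower numbers in this assay is expected, though well short of that whole gap. The estimated change is an 8.7-fold lower number from compound 1 to compound 3 (0.94 log units; beyond the scatter) and it is expected to lie beyond the scatter. For compound 3 the expected value is 300 nM (estimated range 60 nM to 1500 nM) on this read-out.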

Compound 3, half-maximal inhibitory concentration in the HUVEC assay: 1200 nM
The estimate for compound 3 lay 4.0-fold (0.60 log units) below the measured number; the measured number falls inside the stated range.
By their numbers in the HUVEC assay, from the lowest: compound 2; then compound 3; then compound 1.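

Among these compounds, in the HUVEC assay, replacing the hydrogen on this oxygen with (3-methyloxetan-3-yl)methyl gives a 2.2-fold lower number from compound 1 to compound 3 (0.34 log units; beyond the scatter), the only measured change at this position. The step is modest but points towards stronger inhibition, so on this read-out the hydroxy hydrogen of compound 1 is not required, and the position accepts a group of 6 heavy atoms that carries a four-membered non-aromatic ring without any loss of inhibition. In a physicochemical assay for solubility, at pH 6.8 (on this read-out higher numbers stand for higher solubility and lower numbers for lower solubility), compound 1 gives >= 100000 nM as a limit of the assay and not a number. In the physicochemical assay compound 3 gives >= 100000 nM as a limit of the assay and not a number. In the physicochemical assay the step from compound 1 to compound 3 cannot be read, because both values are limits of the assay and not numbers: the limit of >= 100000 nM in the physicochemical assay, at which 2 of the 2 values shown sit.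

The two compounds cannot separate the effect of replacing the hydroxy hydrogen from the effect of the oxetane ring itself; a simple methoxy at the same place on the chain would divide the two, and a primary amine or a carboxylic acid there would test other end groups. As far as these compounds go, a longer chain between the shared core and the end group also remains open, as does any readable difference in solubility for this pair.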